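Notes on a pyrimidine series: swapping the chain terminus

The source may report more compounds than this note shows. Statements on the series, on what has been measured and on what is new or still open speak of the compounds shown alone.

Measured so far in an assay on HEK293 cells for agonist activity at Toll-like receptor 8 (Homo sapiens), read by spectrophotometry; a higher number here means that more compound is needed for the effect, a lower number that less compound is needed:
compound 1 `CCCCCc1c(C)nc(N)nc1NCCCC` gives 1220 nM
compound 2 `CCCCNc1nc(N)nc(C)c1C#CCN1CCCCC1` gives 3790 nM
compound 3 `CCCCNc1nc(N)nc(C)c1CCCn1cccn1` gives 1050 nM

Compound 3 has the lowest number of the three, but its separation from compound 1 is within the scatter, so the two cannot be ordered. Within the data shown here, compound 2 is the only one clearly set apart, with a higher number than compound 3 beyond the scatter; no single-point step links compound 2 to the others.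

Among the measured compounds shown here, the one measured step that touches the terminus of the chain is a 1.2-fold lower number from compound 1 to compound 3 (0.07 log units; within the scatter), where the ring replaced a plain alkyl end without moving the number beyond the scatter.

Compound 4 `CCCCNc1nc(N)nc(C)c1CCCN(C)C` is the next point. The change from compound 3: dimethylamino in place of 1H-pyrazol-1-yl on a saturated chain carbon, three bonds along the chain from an aromatic carbon. The chain length and the rest of the core stay as in compound 3. For the measured compounds named here, only the step from compound 1 to compound 3 bears directly on it, and that step was flat; the high number of compound 2 comes with a different chain and gives no clean read on an amine terminus. The expected step is therefore small, a 1.3-fold higher number from compound 3 to compound 4 (0.12 log units; within the scatter), with a wide range around it.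

For compound 4 in this assay the estimate is 1400 nM, expected between 450 nM and 4500 nM.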

Compound 4, half-maximal effective concentration: 126 nM
Compound 4: middle estimate off by 11-fold (1.05 log units), on the high side; measured number outside the range, below it.
By their numbers in this assay, from the lowest: compound 4; then compounds 3 and 1 (each within the scatter of the next); then compound 2.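

The terminus of this chain is not the flat position that the earlier step suggested: a 1.2-fold lower number from compound 1 to compound 3 (0.07 log units; within the scatter) had left the ethyl and 1H-pyrazol-1-yl ends inseparable in this assay, whereas dimethylamino on a saturated chain carbon, three bonds along the chain from an aromatic carbon, gives an 8.3-fold lower number from compound 3 to compound 4 (0.92 log units; beyond the scatter) and also a 9.7-fold lower number from compound 1 to compound 4 (0.99 log units; beyond the scatter). So the number at this place does depend on the group that ends the chain, and among the three ends compared here on the same chain only dimethylamino stands apart, with no ring and 3 heavy atoms against the 5 heavy atoms and five-membered aromatic ring of 1H-pyrazol-1-yl. Nothing available explains why this one group separates from the other two.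

With a single amine at this place, the compounds shown cannot say whether the gain belongs to amines in general or to dimethylamino alone; diethylamino, a primary amine or a piperidine on the same saturated chain would test that. On these data alone, whether a shorter or longer chain carrying dimethylamino holds the low number also stays open, and compound 2 differs in too many places to answer either question.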